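Methyl-to-hydrogen step on the aryl oxygen, second instance

This account rests on a few compounds, and the source may have more. Where it says the series, first, only, none or still open, it means among the compounds named here.

Compound 1 `COc1cc(-c2nn(-c3cccc(NC(=O)Nc4cc(C(F)(F)F)cc(C(F)(F)F)c4)c3)cc2-c2ccncc2)ccc1Cl` carries a methoxy group on the aryl ring attached to the pyrazole and a bis(trifluoromethyl)phenyl urea. In a functional assay on NCI/ADR-RES cells (Homo sapiens) for inhibition, read by sulforhodamine B assay, with a stated time of 48 h (on this read-out higher numbers stand for weaker inhibition of growth and lower numbers for stronger inhibition of growth), compound 1 gives 1010 nM. Compound 2 `O=C(Nc1cccc(-n2cc(-c3ccncc3)c(-c3ccc(Cl)c(O)c3)n2)c1)Nc1cc(C(F)(F)F)cc(C(F)(F)F)c1` is its demethylated counterpart, differing by hydrogen in place of methyl on an oxygen on an aromatic ring. In this assay compound 2 gives 1070 nM. The step is a 1.1-fold higher number from compound 1 to compound 2 (0.03 log units; within the scatter), so the two values cannot be told apart.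

Compound 3 `COc1cc(-c2nn(-c3cccc(NC(=O)Nc4ccc(Cl)c(C(F)(F)F)c4)c3)cc2-c2ccncc2)ccc1Cl` keeps the methoxy group but carries a 4-chloro-3-(trifluoromethyl)phenyl urea in place of the bis(trifluoromethyl)phenyl urea; how the core of compound 3 differs from that of compound 1 is not broken down here. In this assay compound 3 gives 1040 nM, which lies within the scatter of compound 1 and of compound 2.

Compound 4 `O=C(Nc1cccc(-n2cc(-c3ccncc3)c(-c3ccc(Cl)c(O)c3)n2)c1)Nc1ccc(Cl)c(C(F)(F)F)c1` is not yet measured. It differs from compound 3 by hydrogen in place of methyl on an oxygen on an aromatic ring, the same change that was made from compound 1 to compound 2, at the same place. That earlier step was a 1.1-fold higher number from compound 1 to compound 2 (0.03 log units; within the scatter), a step within the scatter. Within the data shown here, on that basis the step from compound 3 to compound 4 is expected to be about a 1.1-fold higher number from compound 3 to compound 4 (0.02 log units; within the scatter), resting on the single precedent from compound 1 to compound 2. Compound 4 is therefore estimated at 1100 nM in this assay, with a plausible range from 600 nM to 2100 nM.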

Compound 4, concentration for 50% growth inhibition: 844 nM
Estimate against measurement, compound 4: 1.3-fold (0.12 log units) above; measured number inside the range.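

In this assay, the change from methoxy to hydroxy on the 4-chloro-3-methoxyphenyl group gives a 1.2-fold lower number from compound 3 to compound 4 (0.09 log units; within the scatter), and the comparison with the same change on the other core reads: the same change on two cores in this assay, a 1.1-fold higher number (0.03 log units; within the scatter) from compound 1 to compound 2 and a 1.2-fold lower number (0.09 log units; within the scatter) from compound 3 to compound 4, 1.3-fold (0.12 log units) apart, within the scatter of two such steps. On these two cores, the change therefore carries over as a step that cannot be told from the scatter, and neither core gives any sign that the hydroxy and methoxy forms can be separated on this read-out. Among these compounds, this is agreement between two small steps on only two pairs, so it does not show that the change is neutral on other cores or in other cell lines, and it does not test whether a step beyond the scatter would carry from one core to another.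

The compounds shown hold only methoxy or hydroxy at this place, which leaves open whether a longer chain such as ethoxy, an amine or a carboxylic acid there would give a step beyond the scatter in this assay. Also open is whether the flat response seen here would hold on a core with a urea partner other than the two shown.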